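The source may hold more compounds than are shown below. What is called first, only, known or untested is meant among the compounds shown, and "the series" means these compounds.

This account follows the series into its first unmeasured member. Three compounds have been characterized in a functional assay on OE19 cells (Homo sapiens) for cytotoxicity, read by MTT assay, with a stated time of 48 h; a higher number here means a weaker inhibitor, a lower number a stronger inhibitor. Compound 1, whose structure is `CC1(C)S[C@@H]2/C(=C\C(=O)c3ccc4ccccc4c3)C(=O)N2[C@H]1C(=O)OC(c1ccccc1)c1ccccc1`, gives 19500 nM in this assay. Compound 2, with the structure `CC1(C)[C@H](C(=O)OC(c2ccccc2)c2ccccc2)N2C(=O)/C(=C/C(=O)c3ccc([N+](=O)[O-])cc3)[C@H]2[S+]1[O-]`, gives 92400 nM. Compound 3, built as `CC1(C)[C@H](C(=O)OC(c2ccccc2)c2ccccc2)N2C(=O)/C(=C/C(=O)c3ccc([N+](=O)[O-])cc3)[C@H]2S1(=O)=O`, gives 95500 nM.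

Within these three numbers compound 2 stands second highest. Its nearest neighbour is compound 3, whose value sits within the scatter of repeated measurements, so the two cannot be placed in any order. The furthest is compound 1, whose number lies clearly lower, beyond the scatter; since these two compounds differ in more than one place, no single change can be credited for that gap.

Compound 4, the structure `CC1(C)[C@H](C(=O)OC(c2ccccc2)c2ccccc2)N2C(=O)/C(=C/C(=O)c3ccccc3)[C@H]2[S+]1[O-]`, differs from compound 2 in one place: hydrogen in place of nitro on an aromatic carbon. Among the compounds with values here, no pair among the measured compounds shows this change alone, so the size of its effect is unknown here. Given that, the expectation for compound 4 is a step from compound 2 that stays within or close to the scatter, a 1.3-fold lower number from compound 2 to compound 4 (0.12 log units; within the scatter), with a modest lean toward a lower number. Compound 4 is therefore estimated at 70000 nM in this assay, with a range from 25000 nM to 200000 nM.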

Compound 4, half-maximal inhibitory concentration: 23700 nM
Compound 4: middle estimate off by 3.0-fold (0.47 log units), on the high side, outside the stated range (below it).
By their numbers in this assay, from the lowest: compounds 1 and 4 (each within the scatter of the next); then compounds 2 and 3 (each within the scatter of the next).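

Taking the nitro group off the aromatic carbon para to a large group is not a silent change in this assay: the result is a 3.9-fold lower number from compound 2 to compound 4 (0.59 log units; beyond the scatter), a step that stands beyond the scatter. The earlier compounds shown here could not show this, since none of them formed a pair differing at this position alone; this pair now shows that, on this scaffold, the phenyl compound carries the lower number and so is the stronger inhibitor of the two, while the 4-nitrophenyl compound is the weaker. Nothing at hand explains why this step arises or connects it to any property of the nitro group.

From the compounds shown here alone, with only hydrogen and nitro compared at this carbon, it remains open whether the step is specific to nitro or would also appear with another group there, such as an amine, a methoxy group or a chlorine atom. Going by these compounds, it is also open whether hydrogen in place of nitro would give a step of similar size on compound 3, where the rest of the molecule differs from compound 2.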